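The compounds below may be only part of what the source reports. "The series", "measured", "known", "first", "only" and "open" are said of these compounds alone.

Measured compounds:
- compound 1 `COc1ccccc1/C=c1/[nH]c(=O)/c(=C\c2ccccc2OC)n(C)c1=O`: 7000 nM
- compound 2 `C=CCn1c(=O)/c(=C\c2cccc(Cl)c2Cl)[nH]c(=O)/c1=C\c1ccccc1OC`: 2300 nM
- compound 3 `C=CCn1c(=O)/c(=C\c2ccc(Cl)c(Cl)c2)[nH]c(=O)/c1=C\c1ccccc1OC`: "not active" (no number reported)

All three share one core and differ only in the ring carried on one of its double-bonded chain carbons. In a functional assay on A549 cells (Homo sapiens) for cytotoxicity, read by CCK-8 assay, with a stated time of 72 h (on this read-out higher numbers stand for weaker inhibition and lower numbers for stronger inhibition), compound 2 gives 2300 nM, the lowest of the two numbers reported. Its nearest neighbour is compound 1, which gives 7000 nM, a gap that lies beyond the usual scatter. Compound 3 is reported as "not active" (no number reported), without a number, which shows that this ring can make the difference between a measurable value and none.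

Compound 4 `C=CCn1c(=O)/c(=C\c2cc(F)ccc2C)[nH]c(=O)/c1=C\c1ccccc1OC` has not yet been measured. It differs from compound 2 in one place: 5-fluoro-2-methylphenyl in place of 2,3-dichlorophenyl on a double-bonded chain carbon bound to an aromatic carbon. For the measured compounds named here, no measured pair tracks this change, so the size of the step is uncertain. Given that compound 3 with its 3,4-dichlorophenyl fell out of range, a moderate loss is expected from compound 2 to compound 4, roughly a 2.0-fold higher number from compound 2 to compound 4 (0.29 log units; within the scatter). Compound 4 is therefore estimated at 4500 nM in this assay, with a likely range from 1500 nM to 15000 nM.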

Compound 4, half-maximal inhibitory concentration: 4900 nM
Compound 4: middle estimate off by 1.1-fold (0.04 log units), on the low side, and the stated range covers the measured number.
By their numbers in this assay, from the lowest: compound 2; then compounds 4 and 1 (each within the scatter of the next).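

In this assay, putting 5-fluoro-2-methylphenyl in place of 2,3-dichlorophenyl on a double-bonded chain carbon bound to an aromatic carbon gives a 2.1-fold higher number from compound 2 to compound 4 (0.33 log units; beyond the scatter), a modest loss. Chlorine is therefore not needed for a measurable value at this position: compound 4 has no chlorine and still gives a number, whereas compound 3, with its two chlorines, gives none. The two rings have the same heavy-atom count and neither has hydrogen-bond donors or acceptors, so these counts do not account for the step, and nothing available here explains it.

As far as these compounds go, the swap changes every ring substituent at once, so the separate contributions of the fluorine and the methyl remain unknown. From the compounds shown here alone, it also remains open how this position would respond to a ring bearing an amine or a carboxylic acid.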